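Expected Activity of Compound 3 in a Cell Assay

The source may report more compounds than this note shows. Statements on the series, on what has been measured and on what is new or still open speak of the compounds shown alone.

Compound 1 `Cc1nc(-c2ccc(Cl)cc2)sc1C(=O)CSc1nc(-c2ccccc2)c(C#N)c(=O)[nH]1`: 83.1%
Compound 2 `Cc1nc(-c2ccccc2)sc1C(=O)CSc1nc(-c2ccccc2)c(C#N)c(=O)[nH]1`: 87.5%

Among the measured compounds shown here, in a functional assay on U-87MG ATCC cells for antiproliferative activity against U-87 MG (Homo sapiens), read by MTT assay, with a stated time of 48 h, tested at 10 uM (on this read-out higher numbers stand for a weaker effect at the one concentration tested and lower numbers for a stronger effect), compound 1 gives 83.1% and compound 2 gives 87.5%; the single measured step, a number 4.4 percentage points higher from compound 1 to compound 2 (within the scatter), lies within the scatter, so the two stand level. Compound 3 `COc1ccc(-c2nc(SCC(=O)c3sc(-c4ccc(Cl)cc4)nc3C)[nH]c(=O)c2C#N)cc1OC` differs from compound 1 by 3,4-dimethoxyphenyl in place of phenyl on an aromatic carbon. The measured step concerns hydrogen in place of chloro at another position and does not bear on this change; nothing measured here does. The step expected from this change, a number 0.1 percentage points lower from compound 1 to compound 3 (within the scatter), is none beyond the scatter in this assay. Compound 3 is estimated at 83%, with a range from 65% to 96%.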

Compound 3, a percentage reported as activity, at one concentration (the size of the read-out at that concentration, not a potency): 83.3%
Beside the measured number, compound 3's estimate is 0.3 percentage points below it; the range from low to high includes it.
By their numbers in this assay, from the lowest: compounds 1, 3 and 2 (each within the scatter of the next).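

In this assay, 3,4-dimethoxyphenyl in place of phenyl on the aromatic carbon ortho to a cyano group gives a number 0.2 percentage points higher from compound 1 to compound 3 (within the scatter), so the larger group is taken up at this position with the two compounds standing level. This is the only change at this position among the compounds shown, and it was made with the chloro group kept in place. No measured information accounts for this result. On these data alone, whether an amine or a carboxylic acid on this phenyl ring would move the number beyond the scatter stays open. So does whether a single methoxy group would behave as the two together do.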